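The source may report more compounds than this note shows. Statements on the series, on what has been measured and on what is new or still open speak of the compounds shown alone.

Compound 1 `COc1cc(N2C(=O)C(O)C2c2ccc(SC)cc2)cc(OC)c1OC`: 15 nM
Compound 2 `C=CC1C(=O)N(c2cc(OC)c(OC)c(OC)c2)C1c1ccc(SC)cc1`: 61 nM
Compound 3 `COc1cc(N2C(=O)C(C3CC3)C2c2ccc(SC)cc2)cc(OC)c1OC`: 279 nM

In a functional assay on HL-60 cells (Homo sapiens) for inhibition, read by resazurin assay, with a stated time of 72 h (a higher number here means a weaker inhibitor, a lower number a stronger inhibitor), compound 1 gives the lowest of the three numbers. Its nearest neighbour is a 4.1-fold higher number from compound 1 to compound 2 (0.61 log units; beyond the scatter), its furthest a 19-fold higher number from compound 1 to compound 3 (1.27 log units; beyond the scatter), and between the other two lies a 4.6-fold higher number from compound 2 to compound 3 (0.66 log units; beyond the scatter). All three measured steps concern the group on the saturated ring carbon.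

Compound 4 `CCSc1ccc(C2C(O)C(=O)N2c2cc(OC)c(OC)c(OC)c2)cc1` differs from compound 1 in another place: methyl in place of hydrogen on a saturated chain carbon bound to a sulfur. Within the data shown here, no measured step touches this part of the shared core, so none of them bears directly on the change. With nothing pointing either way, the expected step of a 1.5-fold higher number from compound 1 to compound 4 (0.17 log units; within the scatter) is small, likely within the scatter. Compound 4 is therefore estimated at 22 nM, within a range from 7 nM to 70 nM.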

Compound 4, half-maximal inhibitory concentration: 16 nM
For compound 4 the middle estimate is 1.4-fold (0.14 log units) above the measured one; the range from low to high includes it.
By their numbers in this assay, from the lowest: compounds 1 and 4 (each within the scatter of the next); then compound 2; then compound 3.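

In this assay the switch from methylsulfanyl to ethylsulfanyl gives a 1.1-fold higher number from compound 1 to compound 4 (0.03 log units; within the scatter) and so leaves the two compounds level. All earlier steps concerned the group on the saturated ring carbon, where each swap moved the number beyond the scatter, whereas this first step on the sulfur side does not. No measurement here explains this result. One added methyl is a single point, so a longer chain such as propyl, or a hydroxyethyl group, could read differently. Going by these compounds, whether ethylsulfanyl would also match methylsulfanyl alongside the vinyl of compound 2 or the cyclopropyl of compound 3 remains open.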